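Stretching the side chain of a cyclopropane-fused enone

This account rests on a few compounds, and the source may have more. Where it says the series, first, only, none or still open, it means among the compounds named here.

Compound 1 `C/C=C1\C=C(C)C2(CC2)C(C)(O)C1=O` is the reference point of this set. For the measured compounds named here, in a functional assay on SW480 cells (Homo sapiens) for antiproliferative activity (a higher number here means a weaker inhibitor, a lower number a stronger inhibitor), compound 1 gives 120 nM, which is the highest of the two actual numbers recorded; the only other number belongs to compound 3 `CC1=C/C(=C\Cl)C(=O)C(C)(O)C12CC2`, which in this assay gives 30 nM. Compound 2 `CC1=C/C(=C\c2cccs2)C(=O)C(C)(O)C12CC2` reaches only a limit of the assay, > 10000 nM, and is not a number (the limit of > 10000 nM in this assay, at which 1 of the 3 values shown sits). The measured steps are therefore of two kinds: a modest gain a 4.0-fold lower number from compound 1 to compound 3 (0.60 log units; beyond the scatter) when a small halogen takes the place of the methyl, and a large loss an at least 83-fold higher number from compound 1 to compound 2 (1.92 log units; beyond the scatter) when a thiophen-2-yl does so.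

Compound 4 `CC1=C/C(=C\C#CCCO)C(=O)C(C)(O)C12CC2` makes the third change at the same place (4-hydroxybut-1-yn-1-yl in place of methyl on a double-bonded chain carbon bound to a double-bonded ring carbon). It is far bulkier than the chloro of compound 3 yet lacks the ring of compound 2, so neither step maps onto it cleanly. Given the loss seen an at least 83-fold higher number from compound 1 to compound 2 (1.92 log units; beyond the scatter) with a larger substituent and the gain seen a 4.0-fold lower number from compound 1 to compound 3 (0.60 log units; beyond the scatter) with a smaller one, compound 4 is expected to fall between the two, most likely somewhat weaker than compound 1, with the estimated step of a 3.3-fold higher number from compound 1 to compound 4 (0.52 log units; beyond the scatter). The estimated value for compound 4 in this assay is 400 nM, within a range from 80 nM to 3000 nM.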

Compound 4, half-maximal inhibitory concentration: 4000 nM
Beside the measured number, compound 4's estimate is 10-fold (1.00 log units) below it, outside the stated range (above it).
By their numbers in this assay, from the lowest: compound 3; then compound 1; then compound 4. At a limit, above all of these: compound 2.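

In this assay, a substituent on the double-bonded chain carbon bound to a double-bonded ring carbon need not carry a ring to lose most of the activity: 4-hydroxybut-1-yn-1-yl has no ring, yet it gives a 33-fold higher number from compound 1 to compound 4 (1.52 log units; beyond the scatter) and a 130-fold higher number from compound 3 to compound 4 (2.12 log units; beyond the scatter). Its hydrogen-bond donor and acceptor do not restore the activity of compound 1, so of the three replacements shown, only chloro improves on methyl. On these data alone, compound 2 remains at a limit and has no actual number, so its comparison with the chain is one-sided, an at least 2.5-fold lower number from compound 2 to compound 4 (0.39 log units; beyond the scatter), and the true gap is unknown: the limit of > 10000 nM in this assay, at which 1 of the 4 values shown sits.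

The compounds shown leave open whether the loss in compound 4 goes with the triple bond, the terminal hydroxyl or the length of the chain, which a plain but-1-yn-1-yl group or a saturated 4-hydroxybutyl chain would help to separate. They also leave open whether the gain belongs to chloro alone or extends to fluoro or bromo at this place.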